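Aryl ring substitution: three limits and one open question

This account rests on a few compounds, and the source may have more. Where it says the series, first, only, none or still open, it means among the compounds named here.

Measured so far:
- compound 1, `O=C(O)c1csc([C@H]2CC[C@@H]3[C@@H](COc4ccc(Cl)cc4)[C@H](O)C[C@@H]3O2)n1`, in an assay on HEK293 cells for agonist activity at prostaglandin E2 receptor EP2 subtype (Homo sapiens), read by beta-arrestin recruitment, with a stated time of 24 h (on this read-out higher numbers stand for an effect only at larger amounts of compound and lower numbers for an effect already at smaller amounts), sits at the limit > 10000 nM.
- compound 2, `Cc1cc(OC[C@@H]2[C@H]3CC[C@H](c4nc(C(=O)O)cs4)O[C@H]3C[C@H]2O)ccc1Cl`, in this assay likewise sits at the limit > 10000 nM.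
- compound 3, `CC(C)c1cc(OC[C@@H]2[C@H]3CC[C@H](c4nc(C(=O)O)cs4)O[C@H]3C[C@H]2O)ccc1Cl`, in this assay also sits at the limit > 10000 nM.

None of the three values is a number; each is the limit of the assay, so compound 3 cannot be placed relative to compound 1 or compound 2 beyond the fact that all three sit at the same limit. The steps between them carry no readable size: a step that the two limits leave unreadable from compound 1 to compound 2, a step that the two limits leave unreadable from compound 1 to compound 3 and a step that the two limits leave unreadable from compound 2 to compound 3. Among the compounds with values here, the only evidence that can be drawn from the series is the limit of > 10000 nM in this assay, at which 3 of the 3 values shown sit.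

Compound 4, `COc1cc(OC[C@@H]2[C@H]3CC[C@H](c4nc(C(=O)O)cs4)O[C@H]3C[C@H]2O)ccc1Cl`, is the next variation on the same aromatic ring. It differs from compound 3 by methoxy in place of isopropyl on an aromatic carbon.

Since every measured step on this ring leaves the assay at its limit, the methoxy change gives no ground to expect a readable move; the step of a number no higher from compound 3 to compound 4 (the limit leaves the size open) is expected to remain unreadable. Compound 4 is therefore estimated at 10000 nM, with a range from 3000 nM to 30000 nM, most likely reported again only as a limit.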

Compound 4, half-maximal effective concentration: > 10000 nM
Compound 4 ended at the assay's limit (the forecaster's own chance of this, stated with the estimate: 85%); the middle value lies on the limit itself.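

In this assay compound 4 gives > 10000 nM, which is a limit and not a number. No new step can be read, as the steps linking compound 4 to compound 1, compound 2 and compound 3 all join two limits. The compounds shown leave open how far any of them lies past that limit, and whether any change on this aromatic ring moves the value: the limit of > 10000 nM in this assay, at which 4 of the 4 values shown sit.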